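A Read-Out Held at Its Limit

This account rests on a few compounds, and the source may have more. Where it says the series, first, only, none or still open, it means among the compounds named here.

In a functional assay on cells (Mast cell, Rattus norvegicus) for inhibition, with a stated time of 15 min (on this read-out higher numbers stand for an effect only at larger amounts of compound and lower numbers for an effect already at smaller amounts), compound 1 `O=C(O)CCCCCNC(=O)c1cc(=O)c2ccccc2o1` gives > 18 ug/mL, which is a limit of the assay. Compound 2 `O=C(O)CCNC(=O)c1cc(=O)c2ccccc2o1` gives > 18 ug/mL, which is also a limit and not a number. Compound 2 therefore has no exact standing, and the two measured compounds share (the limit of > 18 ug/mL in this assay, at which 2 of the 2 values shown sit). Compound 3 `O=C(O)CCCNC(=O)c1cc(=O)c2ccccc2o1` has not yet been measured. It differs from compound 2 by carboxymethyl in place of carboxy on a saturated chain carbon, two bonds along the chain from an amide-type nitrogen. Among the measured compounds shown here, the one measured step at that place, 3-carboxypropyl going to carboxy, is a step that the two limits leave unreadable from compound 1 to compound 2. It offers no size to carry over, so no step beyond the scatter is expected in this assay. The entering carboxymethyl is shorter than 3-carboxypropyl and longer than carboxy, and a result at the same limit is the likeliest outcome. The expected change is a step that the limit leaves unreadable from compound 2 to compound 3, and this is only an estimate. Compound 3 is estimated at 25 ug/mL, with an expected range from 12 ug/mL to 60 ug/mL.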

Compound 3, concentration for half-maximal effect: > 18 ug/mL
Compound 3 ended at the assay's limit; the forecaster's own chance of this, stated with the estimate: 85%; the middle value is on the limit's open side.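

Compound 3 gives > 18 ug/mL in this assay, which is a limit of the assay and not a number. No step can be read among compound 1, compound 2 and compound 3, which all sit at the same limit: the limit of > 18 ug/mL in this assay, at which 3 of the 3 values shown sit. The compounds shown leave open whether exchanging carboxy for carboxymethyl or 3-carboxypropyl changes the read-out at all.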